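The source may hold more compounds than are shown below. What is called first, only, known or untested is meant among the compounds shown, and "the series" means these compounds.

Compounds measured in an assay on LtK cells with ATP-sensitive inward rectifier potassium channel 11 (Homo sapiens) as the target; a lower number here means that less compound is needed, a higher number that more compound is needed for the effect:

Compound 1, `CCC(=O)Nc1c(C(O)(C(F)(F)F)C(F)(F)F)ccc2ccccc12`, gives 15 nM.
Compound 2, `C/C=C/C(=O)Nc1c(C(O)(C(F)(F)F)C(F)(F)F)ccc2ccccc12`, gives 72 nM.
Compound 3, `O=C(Nc1ccc(Cl)cc1)Nc1c(C(O)(C(F)(F)F)C(F)(F)F)ccc2ccccc12`, gives 276 nM.

Compound 3 carries the highest number of the three. The step from the ethyl amide to it is an 18-fold higher number from compound 1 to compound 3 (1.26 log units; beyond the scatter), and the step from the prop-1-en-1-yl amide to it is a 3.8-fold higher number from compound 2 to compound 3 (0.58 log units; beyond the scatter); compound 2 is the nearer of the two, compound 1 the farther. The smaller step among the measured pair, a 4.8-fold higher number from compound 1 to compound 2 (0.68 log units; beyond the scatter), separates the two amides from each other.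

Compound 4, `O=C(Nc1c(C(O)(C(F)(F)F)C(F)(F)F)ccc2ccccc12)c1ccc(F)cc1`, is not yet measured. It differs from compound 3 in one place: 4-fluorophenyl in place of (4-chlorophenyl)amino on a carbonyl carbon. Among the measured compounds shown here, no measured step makes exactly this exchange, since both steps into compound 3 replace an alkyl or alkenyl group with the (4-chlorophenyl)amino group rather than with another aryl group. What those steps do show is that putting the (4-chlorophenyl)amino group on the carbonyl carbon raised the number well beyond the scatter in both cases. Its departure might therefore recover part of that rise, though the incoming 4-fluorophenyl group is new to this set. Compound 4 is expected to land at 100 nM, with a range of 30 nM to 400 nM; the expected step of a 2.8-fold lower number from compound 3 to compound 4 (0.44 log units; beyond the scatter) is a modest decrease.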

Compound 4, half-maximal effective concentration: 70 nM
Compound 4: the middle estimate sits 1.4-fold (0.15 log units) above what was measured; low and high end bracket the measured number.
By their numbers in this assay, from the lowest: compound 1; then compounds 4 and 2 (each within the scatter of the next); then compound 3.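

In this assay, a 3.9-fold lower number from compound 3 to compound 4 (0.60 log units; beyond the scatter) shows that the high number of compound 3 is not shared by every group with a six-membered aromatic ring of carbon on this carbonyl carbon: both the leaving (4-chlorophenyl)amino and the entering 4-fluorophenyl carry such a ring, yet the step lies beyond the scatter. The 4-fluorophenyl and prop-1-en-1-yl groups cannot be told apart at this place (a 1.0-fold lower number from compound 2 to compound 4 (0.01 log units; within the scatter)), while ethyl keeps the lowest number of the four, now also against an aryl group (a 4.7-fold higher number from compound 1 to compound 4 (0.67 log units; beyond the scatter)). Nothing in the data shown accounts for these steps.

The compounds shown leave open whether the difference between compound 3 and compound 4 goes with the nitrogen and its hydrogen-bond donor or with chlorine against fluorine, as these change together here; a 4-chlorophenyl group or a (4-fluorophenyl)amino group on the same carbonyl carbon would separate the two. Also open, going by these compounds, is how a methyl group, a cyclopropyl group or a longer chain such as butyl would compare with ethyl at this place.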